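Aryl on nitrogen: from bromo to methoxy

The source may hold more compounds than are shown below. What is called first, only, known or untested is meant among the compounds shown, and "the series" means these compounds.

Measured in a functional assay on HeLa cells (Homo sapiens) for antiproliferative activity, read by MTT assay, with a stated time of 72 h; on this read-out lower numbers stand for stronger inhibition and higher numbers for weaker inhibition:
- compound 1 `CCCCn1ccnc1-c1cc(OC)c(OC)c(OC)c1`: > 100000 nM (a limit of the assay, not a number)
- compound 2 `COc1cc(-c2nccn2-c2ccc(Br)cc2)cc(OC)c1OC`: 3300 nM

For the measured compounds named here, compound 2 holds the only actual number so far, since the other result is a limit. Going by the values given here, the single measured step is an at least 30-fold lower number from compound 1 to compound 2 (1.48 log units; beyond the scatter). That step is large and beyond the scatter, but it starts from a limit: the limit of > 100000 nM in this assay, at which 1 of the 2 values shown sits.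

Compound 3 `COc1ccc(-n2ccnc2-c2cc(OC)c(OC)c(OC)c2)cc1` keeps the shared core and changes only the group on the aromatic nitrogen, from 4-bromophenyl to 4-methoxyphenyl: methoxy in place of bromo on an aromatic carbon. The methoxy stands in place of bromo on an aromatic carbon, para to a large group.

The measured step exchanged butyl for an aromatic ring and does not test a change on that ring, so it gives no direction here. The ring stays in compound 3, so its number is expected to lie near that of compound 2 at 3300 nM in this assay, with only a small step at most. The estimated step is a 1.8-fold lower number from compound 2 to compound 3 (0.26 log units; within the scatter). For compound 3 the expected value is 1800 nM, with an estimated range of 200 nM to 15000 nM.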

Compound 3, half-maximal inhibitory concentration: 1200 nM
For compound 3 the middle estimate is 1.5-fold (0.18 log units) above the measured one; measured number inside the range.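

In this assay, for the compounds shown here, a change on the aryl ring itself can now be read for the first time: methoxy in place of bromo on an aromatic carbon, para to a large group, gives a 2.8-fold lower number from compound 2 to compound 3 (0.44 log units; beyond the scatter), so this position responds to the exchange, though the two compounds alone give no cause for the step. Replacing the butyl group on the aromatic nitrogen with 4-methoxyphenyl gives an at least 83-fold lower number from compound 1 to compound 3 (1.92 log units; beyond the scatter), which places a second aryl compound far from compound 1 and supports the earlier large step with a different substituent on the ring. The value of compound 1 is a limit, so this step has a lower bound and no exact size: the limit of > 100000 nM in this assay, at which 1 of the 3 values shown sits.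

On these data alone, with only bromo and methoxy read at this place, it remains open whether a hydroxyl, an amine or a carboxylic acid on the same aromatic carbon would extend the step or reverse it. As far as these compounds go, an unsubstituted phenyl is also open as a reference point, as is a longer chain in place of the butyl group on the aromatic nitrogen.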